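Trimming the Ethyl Group from a Weak Enone Acid

The compounds below may be only part of what the source reports. "The series", "measured", "known", "first", "only" and "open" are said of these compounds alone.

Of the compounds shown here, three built on one shared core have been tested in a functional assay on K562 cells (Homo sapiens) for inhibition, read by MTT assay, with a stated time of 72 h; a lower number here means a stronger inhibitor, a higher number a weaker inhibitor. Compound 1 `CCc1cc(CC)c(C(=O)/C=C/C(=O)O)c(CC)c1` gives 4010 nM, compound 3 `CCc1c(C(=O)/C=C/C(=O)O)cc(C(C)C)cc1C(C)C` gives 5100 nM, and compound 2 `CCc1ccc(C(=O)/C=C/C(=O)O)cc1` gives 5530 nM. The number for compound 2 is the highest of the three, yet every gap between these compounds falls within the usual scatter, so nothing separates them. Compound 4 `O=C(O)/C=C/C(=O)c1ccccc1` differs from compound 2 in one place: hydrogen in place of ethyl on an aromatic carbon. Among the compounds with values here, with no measured pair showing the effect of such a change, the step is estimated to be small, if anything toward a weaker inhibitor, as in a 1.3-fold higher number from compound 2 to compound 4 (0.10 log units; within the scatter). Compound 4 is therefore expected to give about 7000 nM, between 3000 nM and 16000 nM.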

Compound 4, half-maximal inhibitory concentration: 30200 nM
Beside the measured number, compound 4's estimate is 4.3-fold (0.63 log units) below it; measured number outside the range, above it.
By their numbers in this assay, from the lowest: compounds 1, 3 and 2 (each within the scatter of the next); then compound 4.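

Ethyl at this position is not a passive passenger: replacing it with hydrogen gives a 5.5-fold higher number from compound 2 to compound 4 (0.74 log units; beyond the scatter) in this assay, so this single change moves the number clearly, which no earlier comparison could show. Within the data shown here, this is the first measured step at the aromatic carbon para to the group of 7 heavy atoms. Nothing available explains why the number rises.

From the compounds shown here alone, whether a methyl group or a longer chain such as propyl would match ethyl here remains open. So does whether a chlorine atom could take its place.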